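Compound 1 and its sulfur-linked group

The source may hold more compounds than are shown below. What is called first, only, known or untested is meant among the compounds shown, and "the series" means these compounds.

Compound 1 `Cc1cc(Nc2cc(-c3ccccc3)[nH]n2)n2nc(SCCc3ccccc3)nc2n1`: 37400 nM
Compound 2 `Cc1cc(Nc2cc(-c3ccccc3)[nH]n2)n2nc(SCc3ccc(F)cc3)nc2n1`: 35500 nM

Both values come from an ADME assay on GES1 cells (Homo sapiens) for inhibition, read by MTT assay, with a stated time of 72 h (a lower number here means a stronger inhibitor, a higher number a weaker inhibitor), and lie level with each other. Among the measured compounds shown here, the one measured step is a 1.1-fold lower number from compound 1 to compound 2 (0.02 log units; within the scatter), so compound 1 stands together with compound 2 and no measured compound sits apart from it.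

Compound 3 `Cc1cc(Nc2cc(-c3ccccc3)[nH]n2)n2nc(SCc3c(Cl)cccc3Cl)nc2n1` has not yet been measured. It differs from compound 1 by 2,6-dichlorophenyl in place of benzyl on a saturated chain carbon bound to a sulfur. For the measured compounds named here, compound 2 carries its own change at that place, and this is the only step that bears on the new one. That step stayed within the scatter, and it offers no direction. The estimated step is a 1.1-fold lower number from compound 1 to compound 3 (0.05 log units; within the scatter), which means none beyond the scatter is expected. Compound 3 is expected at 33000 nM, within an estimated range of 15000 nM to 70000 nM.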

Compound 3, half-maximal inhibitory concentration: 39600 nM
The estimate for compound 3 lay 1.2-fold (0.08 log units) below the measured number; the range from low to high includes it.
By their numbers in this assay, from the lowest: compounds 2, 1 and 3 (each within the scatter of the next).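

In this assay, 2,6-dichlorophenyl in place of benzyl on a saturated chain carbon bound to a sulfur gives a 1.1-fold higher number from compound 1 to compound 3 (0.02 log units; within the scatter) and the exchange of 4-fluorophenyl for 2,6-dichlorophenyl gives a 1.1-fold higher number from compound 2 to compound 3 (0.05 log units; within the scatter) at this same place. With both steps within the scatter, a group bearing two chlorine atoms now joins the fluorinated one in leaving the number level with that of compound 1, so three different sulfur-linked groups give no separation in this assay. No supporting measurement accompanies these numbers to account for them.

The compounds shown leave open whether a group of another kind at this place, such as an amine or a carboxylic acid on the sulfur-linked chain, would move the number beyond the scatter. They also leave open whether replacing the phenyl on the pyrazole of the shared core, for instance with a pyridine, would do so.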